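Methylsulfanyl for methoxy: expected exposure of compound 3

The compounds below may be only part of what the source reports. "The series", "measured", "known", "first", "only" and "open" are said of these compounds alone.

In an ADME assay on the whole organism (Mus musculus, strain CD-1) for pharmacokinetics, at a dose of 10 mg/kg by the oral route (on this read-out lower numbers stand for lower exposure and higher numbers for higher exposure at the dose given), compound 1 `COc1cc([C@](O)(CCN(C)C)[C@@H](c2cc3cc(Br)ccc3nc2OC)c2cccc(OC)c2F)cc(OC(C)C)n1` gives 9000 ng.h/mL. Compound 2 `COc1cc([C@](O)(CCN(C)C)[C@@H](c2cc3cc(Br)ccc3nc2OC)c2cccc(OC)c2F)cc(SC)n1` gives 4600 ng.h/mL, which lies within the scatter of the value for compound 1, so the two cannot be ranked. Compound 3 `COc1cccc([C@H](c2cc3cc(Br)ccc3nc2OC)[C@@](O)(CCN(C)C)c2cc(SC)nc(SC)c2)c1F` differs from compound 2 by methylsulfanyl in place of methoxy on an aromatic carbon, next to the ring nitrogen. Going by the values given here, the only measured step that bears on this is a 2.0-fold lower number from compound 1 to compound 2 (0.29 log units; within the scatter), which also brings in methylsulfanyl, there in place of isopropoxy, and stays within the scatter. It is indirect evidence, since the group leaving is a different one, and a single step shows no trend. No shift beyond the scatter is therefore expected in this assay. The expected step is a 1.2-fold lower number from compound 2 to compound 3 (0.06 log units; within the scatter). For compound 3 the estimate is 4000 ng.h/mL, with an expected range from 1800 ng.h/mL to 8800 ng.h/mL.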

Compound 3, area under the concentration-time curve: 8400 ng.h/mL
Compound 3: middle estimate off by 2.1-fold (0.32 log units), on the low side; measured number inside the range.
By their numbers in this assay, from the lowest: compounds 2, 3 and 1 (each within the scatter of the next).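

Methylsulfanyl in place of methoxy, on the aromatic carbon next to the ring nitrogen, now has a direct reading in this assay: the data show a 1.8-fold higher number from compound 2 to compound 3 (0.26 log units; within the scatter) and so do not separate the two compounds on this exchange. The wider replacement, which gives a ring with two methylsulfanyl groups and no isopropoxy or methoxy group, shows a 1.1-fold lower number from compound 1 to compound 3 (0.03 log units; within the scatter) and likewise leaves the pair unranked, so none of the three compounds stands apart in exposure. No measurement is available that would account for these numbers.

From the compounds shown here alone, it remains open whether any group at this position gives a step beyond the scatter, for example an amine or a longer chain such as ethylsulfanyl. Going by these compounds, with three compounds on one shared core, it also remains open whether these readings hold on any other core.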